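Alkoxy chain length on a shared chloro-quinoline-type core

The compounds below may be only part of what the source reports. "The series", "measured", "known", "first", "only" and "open" are said of these compounds alone.

Measured so far:
compound 1 `CCCCOc1ccc2c(Cl)ccnc2c1`, 3780 nM
compound 2 `CCCCCCCCOc1ccc2c(Cl)ccnc2c1`, 4500 nM

In a functional assay on DLD-1 cells (Homo sapiens) for cytotoxicity, read by MTT assay, with a stated time of 48 h (a higher number here means a weaker inhibitor, a lower number a stronger inhibitor), compound 1 gives 3780 nM and compound 2 gives 4500 nM. Among the measured compounds shown here, compound 1 is one of only two measured compounds, and its number sits within the scatter of that of compound 2; the one measured step is a 1.2-fold higher number from compound 1 to compound 2 (0.08 log units; within the scatter).

Compound 3 `CC(C)Oc1ccc2c(Cl)ccnc2c1` differs from compound 1 by isopropyl in place of butyl on an oxygen on an aromatic ring. For the measured compounds named here, the only step that bears on it is the chain extension from compound 1 to compound 2, which stayed within the scatter, so lengthening the group on the aromatic oxygen did nothing that can be seen in this assay. Shortening and branching it to isopropyl is a smaller change in the same part of the molecule, and no step beyond the scatter is expected in this assay for compound 3.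

Compound 3 is therefore estimated at 4000 nM, range 1600 nM to 10000 nM, a step of a 1.1-fold higher number from compound 1 to compound 3 (0.02 log units; within the scatter) that is expected to fall within the scatter.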

Compound 3, half-maximal inhibitory concentration: 3240 nM
Compound 3: middle estimate off by 1.2-fold (0.09 log units), on the high side; the measured number falls inside the stated range.
By their numbers in this assay, from the lowest: compounds 3, 1 and 2 (each within the scatter of the next).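

In this assay the swap of butyl for isopropyl on an oxygen on an aromatic ring gives a 1.2-fold lower number from compound 1 to compound 3 (0.07 log units; within the scatter) and adds a shorter, branched group to the longer chain of compound 2 as a second change at this oxygen. Neither step from compound 1 leaves the scatter, so among the three alkyl groups shown, the size and shape of the chain on this oxygen produce no readable change in the number. No measurement in hand offers an explanation for this flat response.

As far as these compounds go, it remains open whether a different kind of group on this oxygen, such as a chain ending in an amine or a carboxylic acid, or a phenyl ring, would move the number beyond the scatter. From the compounds shown here alone, the effect of replacing the chlorine on the shared core with an amine is also open.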